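Trading tert-butyl for cyclopropyl on the ring amine

The source may report more compounds than this note shows. Statements on the series, on what has been measured and on what is new or still open speak of the compounds shown alone.

Among the compounds with values here, compound 2 `CC(C)(C)CN1CCCN(CCn2ccc3ccc(Br)cc32)CC1` is one of two compounds measured in an assay on HEK293 cells for binding affinity to 5-hydroxytryptamine receptor 7 (Homo sapiens), read by radioligand binding, tested at 1 uM (on this read-out higher numbers stand for more inhibition at the one concentration tested (going by the name of the read-out) and lower numbers for less inhibition), where compound 2 gives 70%. Within the data shown here, compound 1 `CN1CCCN(CCn2ccc3ccc(Br)cc32)CC1` gives 93%, so compound 2 stands lowest of the pair, and the only step known so far, a number 23 percentage points lower from compound 1 to compound 2 (beyond the scatter), came from putting tert-butyl in place of hydrogen on a saturated chain carbon bound to an amine nitrogen in a ring.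

Compound 3 `Brc1ccc2ccn(CCN3CCCN(CC4CC4)CC3)c2c1` has not yet been measured. It differs from compound 2 as follows: cyclopropyl in place of tert-butyl on a saturated chain carbon bound to an amine nitrogen in a ring. The step from compound 1 to compound 2 is the only one that bears on this change, and it partly reverses: compound 3 carries a group that, by the count shown, lies between the hydrogen of compound 1 and the tert-butyl of compound 2. A modest rise in this assay, perhaps only at the edge of the scatter, is therefore expected, as a number 12 percentage points higher from compound 2 to compound 3 (beyond the scatter).

Compound 3 is estimated to give 82% in this assay, with a likely range from 66% to 94%.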

Compound 3, a percentage reported as inhibition, at one concentration (the size of the read-out at that concentration, not a potency): 95%
Compound 3: middle estimate off by 13 percentage points, on the low side; the whole stated range lies below it.
By their numbers in this assay, from the lowest: compound 2; then compounds 1 and 3 (each within the scatter of the next).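

In this assay, cyclopropyl in place of tert-butyl on a saturated chain carbon bound to an amine nitrogen in a ring gives a number 25 percentage points higher from compound 2 to compound 3 (beyond the scatter) and shows that the fall seen with tert-butyl does not come with every added group at this place. Cyclopropyl in place of hydrogen at the same place gives a number 2 percentage points higher from compound 1 to compound 3 (within the scatter) and so leaves compound 1 and compound 3 indistinguishable on this read-out, which means that, among these three compounds, only the neopentyl-bearing compound 2 stands apart. Nothing measured here explains why neopentyl and cyclopropylmethyl part ways on this read-out.

From the compounds shown here alone, it remains open whether other groups at this place, such as isopropyl, cyclobutylmethyl or a longer chain, would stay level with compound 1 and compound 3 or fall towards compound 2. Since each number comes from one tested concentration, these readings also leave open whether compound 1 and compound 3 would still match in a full concentration series.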